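A Chlorophenyl for an Ethoxy on a Weak Series

The compounds below may be only part of what the source reports. "The series", "measured", "known", "first", "only" and "open" are said of these compounds alone.

All four compounds share one core. Compound 1 `O=S(=O)(Nc1ccc(F)c(C#Cc2cnc3[nH]ncc3c2)c1F)c1ccccc1` carries phenyl on the sulfonyl sulfur, and in a functional assay on HCT-116 cells (Homo sapiens) for antiproliferative activity, read by MTT assay, with a stated time of 68 h (a higher number here means a weaker inhibitor, a lower number a stronger inhibitor), compound 1 gives > 10000 nM, a limit of the assay rather than a number. Compound 2 `O=S(=O)(Nc1ccc(F)c(C#Cc2cnc3[nH]ncc3c2)c1F)c1ccccn1` gives in this assay a value of > 10000 nM, likewise a limit. The step that the two limits leave unreadable from compound 1 to compound 2 cannot be read, since both ends sit at the limit of > 10000 nM in this assay, at which 2 of the 3 values shown sit. Among the compounds with values here, compound 3 `CCOc1n[nH]c2ncc(C#Cc3c(F)ccc(NS(=O)(=O)c4cccnc4)c3F)cc12` is the only compound with an actual number: in this assay compound 3 gives 10000 nM. Compound 4 `O=S(=O)(Nc1ccc(F)c(C#Cc2cnc3[nH]nc(-c4cccc(Cl)c4)c3c2)c1F)c1cccnc1` differs from it by 3-chlorophenyl in place of ethoxy on an aromatic carbon. No measured step touches this position, so the shown steps give no direction. Compound 4 is therefore expected to sit close to that number, at 6000 nM with a range of 1000 nM to 30000 nM. For compound 4 the expected step of a 1.7-fold lower number from compound 3 to compound 4 (0.22 log units; within the scatter) is none beyond the scatter.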

Compound 4, half-maximal inhibitory concentration: > 10000 nM
Compound 4 was reported as a limit; the forecaster's own chance of this, stated with the estimate: 50%; at least 1.6-fold (0.22 log units) between middle value and limit.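

In this assay, within the data shown here, the first measured step at this position, 3-chlorophenyl in place of ethoxy on the aromatic carbon, gives a number no lower from compound 3 to compound 4 (the limit leaves the size open). The value of compound 4 is a limit and not a number, so the size of this step cannot be read, but the change brought no lower number. Compound 4 thus joins the compounds at the limit: the limit of > 10000 nM in this assay, at which 3 of the 4 values shown sit.

As far as these compounds go, compound 3 stands at 10000 nM, and how an amine or a carboxylic acid on this carbon would read against it stays open.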